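The source may report more compounds than this note shows. Statements on the series, on what has been measured and on what is new or still open speak of the compounds shown alone.

Measured compounds in an assay on cells for inhibition of HSP60/HSP10 (Homo sapiens), with a stated time of 60 min; on this read-out lower numbers stand for stronger inhibition and higher numbers for weaker inhibition:
compound 1, `COc1ccccc1S(=O)(=O)Nc1ccc2oc(-c3ccccc3)nc2c1`, gives > 100000 nM, a limit of the assay.
compound 2, `O=S(=O)(Nc1ccc2oc(-c3ccccc3)nc2c1)c1cccc(O)c1`, gives 76000 nM.

Among the measured compounds shown here, compound 2 stands as the only compound with a number in this assay; the other value shown is a limit. The step of an at least 1.3-fold lower number from compound 1 to compound 2 (0.11 log units; that floor lies within the scatter) lies within the scatter, and one end of it is the limit (the limit of > 100000 nM in this assay, at which 1 of the 2 values shown sits). Compound 3, `O=S(=O)(Nc1ccc2oc(-c3ccccc3)nc2c1)c1cccs1`, is not yet measured. It differs from compound 2 by thiophen-2-yl in place of 3-hydroxyphenyl on a sulfonyl sulfur. For the measured compounds named here, the one measured step also exchanged the ring on the sulfonyl sulfur, and it produced no change beyond the scatter, so the expectation for compound 3 in this assay is a step of a 1.1-fold higher number from compound 2 to compound 3 (0.02 log units; within the scatter), with no direction beyond the scatter. Compound 3 is therefore estimated at 80000 nM, with a range from 30000 nM to 200000 nM, and a considerable chance that only a limit is reported.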

Compound 3, half-maximal inhibitory concentration: 90000 nM
Estimate against measurement, compound 3: 1.1-fold (0.05 log units) below, within the range that was stated.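

In this assay, the exchange of 3-hydroxyphenyl for thiophen-2-yl on the sulfonyl sulfur gives a 1.2-fold higher number from compound 2 to compound 3 (0.07 log units; within the scatter). Among the compounds shown here, this is the first step at this position with a number at both ends, and it shows that a five-membered aromatic ring with no hydrogen-bond donor stands within the scatter of a six-membered carbon ring that carries one. The other new step, an at least 1.1-fold lower number from compound 1 to compound 3 (0.04 log units; that floor lies within the scatter), can be read only as a floor, because compound 1 stands at a limit: the limit of > 100000 nM in this assay, at which 1 of the 3 values shown sits.

As far as these compounds go, it remains open whether any group on the sulfonyl sulfur can bring the number clearly down from this level, for instance a phenyl ring carrying an amine or a carboxylic acid, or a longer alkyl chain in place of the ring. From the compounds shown here alone, what changes elsewhere on the shared core would do also remains open.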